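The compounds below may be only part of what the source reports. "The series", "measured", "known", "first", "only" and "open" are said of these compounds alone.

Compounds measured so far in a functional assay on MGC-803 cells (Homo sapiens) for antiproliferative activity, read by MTT assay, with a stated time of 72 h; on this read-out lower numbers stand for stronger inhibition and higher numbers for weaker inhibition

- Compound 1 `C/C(=N\NC(=O)c1cccc(S(=O)(=O)N2CCOCC2)c1)c1cccc(N)c1O` gives 530 nM
- Compound 2 `CCN(CC)c1ccc(/C=N/NC(=O)c2cccc(S(=O)(=O)N3CCOCC3)c2)c(O)c1` gives 4040 nM
- Compound 3 `COc1ccc(/C=N/NC(=O)c2cccc(S(=O)(=O)N3CCOCC3)c2)c(O)c1` gives 2070 nM

Compound 3, at 2070 nM, lies within the scatter of compound 2, while compound 1, at 530 nM, stands clearly lower. Compound 4 `O=C(N/N=C/c1cc(Br)cc(Br)c1O)c1cccc(S(=O)(=O)N2CCOCC2)c1` has not yet been measured. It carries 3,5-dibromo-2-hydroxyphenyl in place of 2-hydroxy-4-methoxyphenyl on a carbon with a double bond to nitrogen. Among the measured compounds shown here, one measured step touches this same group: a 2.0-fold lower number from compound 2 to compound 3 (0.29 log units; within the scatter), where methoxy replaces diethylamino on an aromatic carbon. For the measured compounds named here, that step stays within the scatter, but it is only weak guidance, since no measured compound carries bromine. No step beyond the scatter is therefore expected in this assay, and no firm direction can be assigned. The estimated change is a 1.2-fold lower number from compound 3 to compound 4 (0.06 log units; within the scatter), with wide margins on either side. For compound 4 the expected value is 1800 nM, with an estimated range of 500 nM to 6000 nM.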

Compound 4, half-maximal inhibitory concentration: 17800 nM
Beside the measured number, compound 4's estimate is 9.9-fold (1.00 log units) below it, and the stated range ends below it.
By their numbers in this assay, from the lowest: compound 1; then compounds 3 and 2 (each within the scatter of the next); then compound 4.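

In this assay, 3,5-dibromo-2-hydroxyphenyl in place of 2-hydroxy-4-methoxyphenyl on a carbon with a double bond to nitrogen gives an 8.6-fold higher number from compound 3 to compound 4 (0.93 log units; beyond the scatter), so the group at this position can weaken inhibition. Among the compounds shown here, the earlier step at this position, a 2.0-fold lower number from compound 2 to compound 3 (0.29 log units; within the scatter), stayed within the scatter, so this pair is the first to show that the substituents on this ring can move the number beyond it. Nothing measured here accounts for the rise.

Two bromine atoms enter as the methoxy group leaves, and the compounds shown cannot separate the loss of methoxy from the gain of either bromine. On these data alone, whether a single bromine, or chlorine in its place, would leave the number closer to that of compound 3 remains open.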